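This account rests on a few compounds, and the source may have more. Where it says the series, first, only, none or still open, it means among the compounds named here.

Working notes on the series. In a functional assay on MCF7 cells (Homo sapiens) for inhibition, read by sulforhodamine B assay, with a stated time of 72 h (a lower number here means a stronger inhibitor, a higher number a weaker inhibitor), compound 1 `O=C(/C=C/c1cn(-c2ccccc2)nc1-c1ccsc1)c1ccccc1` gives 1900 nM, and compound 2 `O=C(/C=C/c1cn(-c2ccccc2)nc1-c1cccnc1)c1c[nH]c2ccccc12` gives 2600 nM; the two numbers sit within the scatter of each other, so compound 2 cannot be separated from compound 1 on this assay. Compound 3 `O=C(/C=C/c1cn(-c2ccccc2)nc1-c1cccnc1)c1ccccc1` differs from compound 2 by phenyl in place of 1H-indol-3-yl on a carbonyl carbon. Among the measured compounds shown here, no measured pair shows this change, so the expected step in this assay from compound 2 to compound 3 is estimated as a 1.3-fold lower number from compound 2 to compound 3 (0.11 log units; within the scatter), nothing beyond the scatter. Compound 3 is therefore expected to give about 2000 nM, with a range of 800 nM to 5000 nM.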

Compound 3, half-maximal inhibitory concentration: 4100 nM
Compound 3: the middle estimate sits 2.1-fold (0.31 log units) below what was measured, and the stated range covers the measured number.
By their numbers in this assay, from the lowest: compounds 1, 2 and 3 (each within the scatter of the next, the first and the last beyond it).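

In this assay, phenyl in place of 1H-indol-3-yl on a carbonyl carbon gives a 1.6-fold higher number from compound 2 to compound 3 (0.20 log units; within the scatter), so this pair does not separate the two groups at this position. Pyridin-3-yl in place of thiophen-3-yl on an aromatic carbon gives a 2.2-fold higher number from compound 1 to compound 3 (0.33 log units; beyond the scatter), a modest step and the only one here that clears the scatter. No available data explain either step. Still open, going by these compounds, is whether an amine or a carboxylic acid on the carbonyl carbon's aromatic ring would shift the number beyond the scatter.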